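This account rests on a few compounds, and the source may have more. Where it says the series, first, only, none or still open, it means among the compounds named here.

Measured compounds:
compound 1, `Cc1nc(SCC(=O)Nc2nc(-c3ccc(Cl)cc3)cs2)n(Nc2ccccc2)c1C`, 3420 nM
compound 2, `Cc1ccc(Nn2c(SCC(=O)Nc3nc(-c4ccccc4)cs3)nc(C)c2C)cc1`, 3410 nM

Both numbers come from a functional assay on Hs-578T cells (Homo sapiens) for antiproliferative activity, read by sulforhodamine B assay, with a stated time of 48 h; on this read-out higher numbers stand for weaker inhibition of growth and lower numbers for stronger inhibition of growth. In this assay compound 1 gives 3420 nM and compound 2 gives 3410 nM; the two values lie within the scatter of each other, so compound 1 cannot be set apart from compound 2 on these numbers. Compound 2 differs from compound 1 in more than one place, so no single step can be read from the pair; the pair shows only that the two structures end at the same level.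

Compound 3, `COc1ccc(Nn2c(SCC(=O)Nc3nc(-c4ccc(Cl)cc4)cs3)nc(C)c2C)cc1`, has not been measured in this assay. It differs from compound 1 by methoxy in place of hydrogen on an aromatic carbon of the anilino ring. Within the data shown here, the two measured compounds give no step at this position, and no other step exists. The expectation for this assay is therefore a change within the scatter, in no particular direction: the step of a 1.1-fold lower number from compound 1 to compound 3 (0.03 log units; within the scatter) is expected to stay inside the usual spread. Compound 3 is estimated at 3200 nM, in the range 1500 nM to 7000 nM.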

Compound 3, concentration for 50% growth inhibition: 11800 nM
Compound 3: the middle estimate sits 3.7-fold (0.57 log units) below what was measured, and the stated range ends below it.
By their numbers in this assay, from the lowest: compounds 2 and 1 (each within the scatter of the next); then compound 3.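

In this assay the anilino ring of compound 1 proves responsive at the carbon para to a large group: phenyl to 4-methoxyphenyl gives a 3.5-fold higher number from compound 1 to compound 3 (0.54 log units; beyond the scatter) and so moves the series toward weaker inhibition of growth. The earlier compounds shown here offered no step at this position, and their matching levels gave no sign that this ring could shift the read-out. This remains a single step with a single substituent on the core of compound 1, and nothing measured here accounts for its direction or size.

Going by these compounds, whether the change belongs to methoxy itself or to any group at this carbon stays open; a hydroxyl, a fluorine, a dimethylamino group or a longer alkoxy chain such as ethoxy at the same place would separate these readings. Also open, on these data alone, is whether the same change would carry over to the core of compound 2, where the anilino ring already holds a different group and the other aromatic ring lacks the chlorine of compound 1.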